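This account rests on a few compounds, and the source may have more. Where it says the series, first, only, none or still open, it means among the compounds named here.

Measured in an ADME assay on BCBL1 cells (Homo sapiens) for cytotoxicity, with a stated time of 7 days (on this read-out lower numbers stand for higher toxicity in this test and higher numbers for lower toxicity in this test), each value a limit:
- compound 1 `C=CCOc1nc(N)nc2c1ncn2/C=C1/CC1(CO)CO`: > 20000 nM
- compound 2 `CCOc1nc(N)nc2c1ncn2/C=C1/CC1(CO)CO`: > 20000 nM
- compound 3 `COCCOc1nc(N)nc2c1ncn2/C=C1/CC1(CO)CO`: > 20000 nM

Compound 3 offers no exact number, only the limit > 20000 nM. All three compounds share (the limit of > 20000 nM in this assay, at which 3 of the 3 values shown sit).

Compound 4 `Nc1nc(OCc2ccccc2)c2ncn(/C=C3/CC3(CO)CO)c2n1` differs from compound 3 by phenyl in place of methoxymethyl on a saturated chain carbon bound to an oxygen on an aromatic ring. In words, it carries phenyl in place of methoxymethyl on a saturated chain carbon bound to an oxygen on an aromatic ring.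

The measured steps in this part of the structure are a step that the two limits leave unreadable from compound 1 to compound 2, a step that the two limits leave unreadable from compound 1 to compound 3 and a step that the two limits leave unreadable from compound 2 to compound 3. None of them gives a size to carry over. Going by the limit of > 20000 nM in this assay, at which 3 of the 3 values shown sit, the expected a number no higher from compound 3 to compound 4 (the limit leaves the size open) in this assay is none beyond the scatter, with no direction expected.

For compound 4 the estimated value is 20000 nM, with an expected range from 9000 nM to 40000 nM.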

Compound 4, half-maximal cytotoxic concentration: > 20000 nM
Compound 4: only a limit was reported (the forecaster's own chance of this, stated with the estimate: 75%); the middle value sits exactly at the limit.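

Among these compounds, compound 4 reports only a limit, as do compounds 1, 2 and 3, so no step between them can be read in this assay: the limit of > 20000 nM in this assay, at which 4 of the 4 values shown sit. The compounds shown leave open whether exchanging these groups changes cytotoxicity at all.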